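Chloro for methyl on the anilino ring of compound 3

The compounds below may be only part of what the source reports. "The series", "measured", "known", "first", "only" and "open" are said of these compounds alone.

Measured so far:
compound 1 `Cc1cccc(Nc2nc(N)nc(COc3ccc4c(C)cc(=O)oc4c3)n2)c1` gives 1780 nM
compound 2 `Cc1cc(=O)oc2cc(OCc3nc(N)nc(Nc4ccc(C5CC5)cc4)n3)ccc12` gives 700 nM
compound 3 `Cc1ccc(Nc2nc(N)nc(COc3ccc4c(C)cc(=O)oc4c3)n2)cc1C` gives 210 nM

In an assay on COS-7 cells for agonist activity at Free fatty acid receptor 1 (Homo sapiens), read by scintillation counting and inositol phosphate accumulation, with a stated time of 90 min (on this read-out lower numbers stand for an effect already at smaller amounts and higher numbers for an effect only at larger amounts of compound), compound 3 stands lowest of the three numbers; its nearest neighbour is compound 2, with a 3.3-fold lower number from compound 2 to compound 3 (0.52 log units; beyond the scatter), and the furthest is compound 1, with an 8.5-fold lower number from compound 1 to compound 3 (0.93 log units; beyond the scatter).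

Compound 4 `Cc1cc(Nc2nc(N)nc(COc3ccc4c(C)cc(=O)oc4c3)n2)ccc1Cl` has not been measured. The change from compound 3 is chloro in place of methyl on an aromatic carbon.

Within the data shown here, two measured steps bear on this position. The step from compound 1 to compound 3, an 8.5-fold lower number from compound 1 to compound 3 (0.93 log units; beyond the scatter), shows that filling this carbon with a methyl group instead of hydrogen brought a clearly lower number. The step from compound 2 to compound 3, a 3.3-fold lower number from compound 2 to compound 3 (0.52 log units; beyond the scatter), changes the whole anilino substituent and speaks less directly. Among the measured compounds shown here, no measured pair tests chloro against methyl at this carbon, so the direction of the exchange cannot be read from the series. Since the position stays occupied by a group of the same size in heavy atoms, compound 4 is expected to sit close to compound 3, with the step of a 1.2-fold higher number from compound 3 to compound 4 (0.08 log units; within the scatter) expected to lie within the scatter. The estimate for compound 4 in this assay is 250 nM, with a range from 100 nM to 650 nM.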

Compound 4, half-maximal effective concentration: 240 nM
Compound 4: middle estimate off by 1.0-fold (0.02 log units), on the high side, and the stated range covers the measured number.
By their numbers in this assay, from the lowest: compounds 3 and 4 (each within the scatter of the next); then compound 2; then compound 1.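

In this assay the exchange of methyl for chloro on this aromatic carbon, ortho to a methyl group and para to a large group, gives a 1.1-fold higher number from compound 3 to compound 4 (0.06 log units; within the scatter) and leaves no readable difference between the two groups here. Until now, only methyl had been compared with hydrogen at this carbon; chloro in place of hydrogen gives a 7.4-fold lower number from compound 1 to compound 4 (0.87 log units; beyond the scatter) as well, so the lower number seen on filling this carbon is not confined to methyl. Against the 4-cyclopropylphenyl of compound 2, the 4-chloro-3-methylphenyl group gives a 2.9-fold lower number from compound 2 to compound 4 (0.46 log units; beyond the scatter) and so, like 3,4-dimethylphenyl, sits at a lower number than that group.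

With the neighbouring methyl kept, the compounds shown carry only hydrogen, methyl and chloro on this carbon, so the outcome with fluoro, methoxy, an amine or a carboxylic acid there stays open. The data on hand offer no explanation for why methyl and chloro read alike at this carbon.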